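Ring size of the amine on the shared core

The source may hold more compounds than are shown below. What is called first, only, known or untested is meant among the compounds shown, and "the series" means these compounds.

Measured compounds in an in vitro functional assay on cells for antagonist activity at metabotropic glutamate receptor 1 (Rattus norvegicus), read by inositol phosphate accumulation; on this read-out lower numbers stand for stronger inhibition and higher numbers for weaker inhibition:
compound 1 `CC1(C)CC(=O)c2cc(C#N)c(SCc3ccccc3)nc2C1` gives 4800 nM
compound 2 `CC1(C)CC(=O)c2cc(C#N)c(NC3CCCCC3)nc2C1` gives 4000 nM
compound 3 `CCc1nc(C#N)c(N2CCc3ccccc3CC2)nc1C` gives 6 nM

Compound 2 stands second highest of the three numbers. Its nearest neighbour is compound 1, whose number sits within the scatter of compound 2, so the two read as the same. Compound 3, on a different core, sits far below both, and that gap lies beyond the scatter. Going by the values given here, no pair of measured compounds differs in one place only, so no single step has been measured in this set.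

Compound 4 `CC1(C)CC(=O)c2cc(C#N)c(NC3CCCC3)nc2C1` is the unmeasured partner of compound 2. The change is cyclopentyl in place of cyclohexyl on a nitrogen on an aromatic ring. The amine nitrogen and the rest of the core of compound 2 are kept; only the carbon ring on that nitrogen shrinks by one member.

With no measured step of this kind in the series, the expectation rests on compound 2 alone at 4000 nM. The step from compound 2 to compound 4 is expected to be a 1.1-fold higher number from compound 2 to compound 4 (0.05 log units; within the scatter), that is, no change beyond the scatter in either direction. Compound 4 is therefore estimated at 4500 nM, with a range from 1500 nM to 13000 nM, a wide band that reflects the absence of any comparable measured step.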

Compound 4, half-maximal inhibitory concentration: 78 nM
Compound 4: the middle estimate sits 58-fold (1.76 log units) above what was measured; the measured number lies below the stated range.
By their numbers in this assay, from the lowest: compound 3; then compound 4; then compounds 2 and 1 (each within the scatter of the next).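

In this assay, replacing the six-membered carbon ring with the five-membered one on a nitrogen on an aromatic ring gives a 51-fold lower number from compound 2 to compound 4 (1.71 log units; beyond the scatter), with the amine nitrogen and the rest of the shared core unchanged. Going by these compounds alone, this is the first single-place step, and it shows that the carbon ring on this nitrogen strongly affects the read-out: a change this small is enough to produce a large step. No available measurement bears on the reason for a step of this size.

With only cyclohexyl and cyclopentyl compared at this position, a single step cannot show whether the number keeps falling with cyclobutyl or rises again with cycloheptyl, or whether the ring itself is needed, as an open chain such as isopropyl or n-pentyl would test. Also open, on these data alone, is whether cyclopentyl gives a comparable step on other cores or with sulfur in place of the amine nitrogen, and how a benzyl group on that nitrogen would read on the shared core.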